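The source may hold more compounds than are shown below. What is called first, only, known or untested is meant among the compounds shown, and "the series" means these compounds.

Measured so far in a functional assay on K562 cells (Homo sapiens) for inhibition, read by MTT assay, with a stated time of 72 h; on this read-out lower numbers stand for stronger inhibition and higher numbers for weaker inhibition:

- compound 1 `CC(C)c1ccc(C(=O)/C=C/C(=O)O)cc1` gives 5560 nM
- compound 2 `CC(C)(C)c1ccc(C(=O)/C=C/C(=O)O)cc1` gives 4330 nM
- compound 3 `CC(C)c1ccc(C(=O)/C=C/C(=O)O)c(C(C)C)c1` gives 4680 nM

These three numbers form a tight group. Compound 3 (at 4680 nM) lies within the usual scatter of both compound 1 and compound 2, so no order among them can be claimed.

The next compound to test is compound 4 `CC(C)c1cc(C(C)C)c(C(=O)/C=C/C(=O)O)c(C(C)C)c1`. It differs from compound 3 by one change, isopropyl in place of hydrogen on an aromatic carbon, ortho to a (2-carboxyethenyl)carbonyl group (isopropyl in place of hydrogen on an aromatic carbon).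

For the measured compounds named here, the closest precedent is the same swap of hydrogen for isopropyl on an aromatic carbon, which gave a 1.2-fold lower number from compound 1 to compound 3 (0.07 log units; within the scatter). Adding a methyl on the saturated chain carbon of the isopropyl group gave a 1.3-fold lower number from compound 1 to compound 2 (0.11 log units; within the scatter). Neither added carbon moved the number measurably, so no step beyond the scatter is expected here, in either direction. Going by the values given here, no measured compound carries as many isopropyl groups as compound 4, so the range has to stay fairly wide.

The expected step is a 1.1-fold lower number from compound 3 to compound 4 (0.05 log units; within the scatter).

For compound 4 the estimated value is 4200 nM, with an expected range from 2000 nM to 8500 nM.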

Compound 4, half-maximal inhibitory concentration: 4670 nM
For compound 4 the middle estimate is 1.1-fold (0.05 log units) below the measured one, within the range that was stated.
By their numbers in this assay, from the lowest: compounds 2, 4, 3 and 1 (each within the scatter of the next).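

In this assay, putting an isopropyl group on this aromatic carbon, ortho to a (2-carboxyethenyl)carbonyl group and meta to two isopropyl groups, gives a 1.0-fold lower number from compound 3 to compound 4 (0.00 log units; within the scatter). The earlier swap of hydrogen for isopropyl, a 1.2-fold lower number from compound 1 to compound 3 (0.07 log units; within the scatter), concerned a different ring position, so this result extends the picture: at a second place on the ring, the same swap also produces no step beyond the usual scatter, even with two isopropyl groups already present. No separate measurement bears on this result, so the data offer no explanation for it.

All the ring changes shown so far add only saturated carbon groups, so it remains open whether a different kind of group on this aromatic carbon, such as an amine or a methoxy group, would also stay within the scatter or would move the number clearly. From the compounds shown here alone, it is equally open how much the number depends on the shared (2-carboxyethenyl)carbonyl group, for instance if its carboxylic acid gave way to a methyl ester or an amide.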